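A few compounds are considered here, and "the series" means these few. Any claim that something is new, unique, unknown or untested is made for them only; others in the source may bear on it.

Compound 1, `CCCCCCCCN1CCC(c2c[nH]c3ccc(NC(=O)c4ccc(F)cc4)cc23)CC1`: in an assay on CHO-K1 cells for displacement of a labelled ligand from 5-hydroxytryptamine receptor 1D (Homo sapiens), read by scintillation counting (on this read-out higher numbers stand for weaker inhibition and lower numbers for stronger inhibition), compound 1 gives > 1000 nM.
Compound 2, `CN(C)CCCN1CCC(c2c[nH]c3ccc(NC(=O)c4ccc(F)cc4)cc23)CC1`: in this assay compound 2 gives > 1000 nM.

Both values are limits of the assay, not numbers; compound 2 therefore stands only at the limit, as does compound 1 (the limit of > 1000 nM in this assay, at which 2 of the 2 values shown sit). Among the compounds with values here, the one measured step, a step that the two limits leave unreadable from compound 1 to compound 2, is unreadable between two limits. Compound 3, `O=C(O)CCCCCCCCCN1CCC(c2c[nH]c3ccc(NC(=O)c4ccc(F)cc4)cc23)CC1`, differs from compound 2 by 6-carboxyhexyl in place of dimethylamino on a saturated chain carbon, three bonds along the chain from an amine nitrogen in a ring. Within the data shown here, no measured step sets a readable size or direction for this change, so the expectation rests on the shared limit alone. Compound 3 is expected to give 1500 nM, with a range from 200 nM to 10000 nM. The expected step is a step that the limit leaves unreadable from compound 2 to compound 3.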

Compound 3, inhibition constant: > 1000 nM
Compound 3 gave a limit, no number; the forecaster's own chance of this, stated with the estimate: 70%; the middle value does not contradict the limit.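

Within the data shown here, no step among compound 1, compound 2 and compound 3 can be read, since all three values are limits, not numbers: the limit of > 1000 nM in this assay, at which 3 of the 3 values shown sit. The compounds shown leave open what actual value each would give in this assay, and whether these chain changes shift it at all.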